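Swapping the benzyl ring substituent in a shared core

The source may report more compounds than this note shows. Statements on the series, on what has been measured and on what is new or still open speak of the compounds shown alone.

Compound 1 `OC[C@H]1O[C@@H](n2cnc3c(NCc4ccc(Cl)cc4Cl)ncnc32)[C@H](O)[C@@H]1O` carries a 2,4-dichlorophenyl group on a saturated chain carbon bound to a nitrogen on an aromatic ring of the shared core. In a functional assay on HOS cells (Homo sapiens) for antiproliferative activity, with a stated time of 72 h (on this read-out higher numbers stand for weaker inhibition and lower numbers for stronger inhibition), compound 1 returns only a limit of the assay, > 166000 nM. Compound 2 `COc1ccc(CNc2ncnc3c2ncn3C2OC(CO)[C@@H](O)[C@H]2O)c(O)c1` likewise gives only a limit in this assay, > 166000 nM. Compound 3 `COc1cc(O)cc(OC)c1CNc1ncnc2c1ncn2[C@@H]1O[C@H](CO)[C@@H](O)[C@H]1O` also sits at a limit in this assay, > 166000 nM. Going by the values given here, every value gathered so far is therefore the same limit, (the limit of > 166000 nM in this assay, at which 3 of the 3 values shown sit), so compound 1 cannot be placed relative to the others, and no measured step between any two compounds exists.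

Compound 4 `OC[C@H]1O[C@@H](n2cnc3c(NCc4ccc(C(F)(F)F)cc4)ncnc32)[C@H](O)[C@@H]1O` differs from compound 1 by 4-(trifluoromethyl)phenyl in place of 2,4-dichlorophenyl on a saturated chain carbon bound to a nitrogen on an aromatic ring. Among the compounds with values here, with all three measured compounds sitting at the limit and no measured step to lean on, the step for this assay is expected to be a step that the limit leaves unreadable from compound 1 to compound 4, that is, nothing beyond the usual scatter. Compound 4 is accordingly estimated at 200000 nM in this assay, with a range from 50000 nM to 600000 nM, most likely reported as a further limit.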

Compound 4, half-maximal inhibitory concentration: > 166000 nM
Compound 4 gave a limit, no number; the forecaster's own chance of this, stated with the estimate: 80%; the middle value does not contradict the limit.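

In this assay compound 4 gives only a limit, > 166000 nM. Going by these compounds alone, compound 1 also stands at a limit, so no step between compound 1 and compound 4 can be read: the limit of > 166000 nM in this assay, at which 4 of the 4 values shown sit. The compounds shown leave open whether any benzyl ring substituent on the shared core gives a readable value in this assay.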